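The source may hold more compounds than are shown below. What is called first, only, known or untested is meant among the compounds shown, and "the series" means these compounds.

Compound 3 `CCCCCCCC/C=C\CCCCCCC(=O)c1nccn1C` gives only a limit in an assay on isolated protein for inhibition of Fatty-acid amide hydrolase 1 (Homo sapiens) (a higher number here means a weaker inhibitor, a lower number a stronger inhibitor), > 100000 nM (the limit of > 100000 nM in this assay, at which 1 of the 3 values shown sits). Compound 1 `CCCCCCCC/C=C\CCCCCCC(=O)c1nc2cccnc2o1` gives 11 nM in this assay, and compound 2 `CCCCCCCC/C=C\CCCCCCC(=O)c1nc2cnccc2o1` gives 7.2 nM, with a 1.5-fold lower number from compound 1 to compound 2 (0.18 log units; within the scatter). The steps onto the limit are an at least 9000-fold higher number from compound 1 to compound 3 (3.95 log units; beyond the scatter) and an at least 13000-fold higher number from compound 2 to compound 3 (4.14 log units; beyond the scatter). Compound 4 `CCCCCCCC/C=C\CCCCCCC(=O)c1ccncn1` carries pyrimidin-4-yl in place of 1-methyl-1H-imidazol-2-yl on a carbonyl carbon. Among the compounds with values here, no measured step covers this exchange; the two large steps show only that the group on the carbonyl carbon of compound 3 loses what the groups on the carbonyl carbon of compound 1 and compound 2 hold. A partial recovery is expected, an at least 200-fold lower number from compound 3 to compound 4 (2.30 log units; beyond the scatter), its size uncertain. Compound 4 is therefore estimated at 500 nM in this assay, between 20 nM and 20000 nM.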

Compound 4, inhibition constant: 110 nM
Beside the measured number, compound 4's estimate is 4.5-fold (0.66 log units) above it, within the range that was stated.
By their numbers in this assay, from the lowest: compounds 2 and 1 (each within the scatter of the next); then compound 4. At a limit, above all of these: compound 3.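

On a carbonyl carbon, pyrimidin-4-yl in place of 1-methyl-1H-imidazol-2-yl restores measurable inhibition in this assay, with an at least 900-fold lower number from compound 3 to compound 4 (2.95 log units; beyond the scatter). Compound 3 gives only a limit, so that step is a bound and not a size: the limit of > 100000 nM in this assay, at which 1 of the 4 values shown sits. The single six-membered ring does not match the groups of the earlier active compounds, with a 10-fold higher number from compound 1 to compound 4 (1.00 log units; beyond the scatter) and a 15-fold higher number from compound 2 to compound 4 (1.18 log units; beyond the scatter).

Going by these compounds, whether a pyridin-2-yl or pyrimidin-2-yl group would hold the same level remains open. Also open, on these data alone, is how a carboxylic acid on the pyrimidin-4-yl ring, or a shorter chain, would change the number.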